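The compounds below may be only part of what the source reports. "The series", "measured", "known", "first", "only" and "open" are said of these compounds alone.

Measured so far in a functional assay on LNCaP cells (Homo sapiens) for antiproliferative activity, read by WST assay, with a stated time of 3 days; a higher number here means a weaker inhibitor, a lower number a stronger inhibitor:
- Compound 1 `CCCCCOc1c(-c2cc(OC)c(OC)c(OC)c2)oc2ccccc2c1=O`: 15400 nM
- Compound 2 `CCCC(C)Oc1c(-c2cc(OC)c(OC)c(OC)c2)oc2ccccc2c1=O`: 15100 nM

Among the compounds with values here, compound 2, at 15100 nM, stands level with the only other measured compound. Within the data shown here, the single measured step, a 1.0-fold lower number from compound 1 to compound 2 (0.01 log units; within the scatter), lies within the scatter, so the two cannot be told apart in this assay.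

Compound 3 `CCN(CC)CCCCOc1c(-c2cc(OC)c(OC)c(OC)c2)oc2ccccc2c1=O` keeps the shared core and changes only the chain: 4-(diethylamino)butyl in place of 1-methylbutyl on an oxygen on an aromatic ring. It carries 4-(diethylamino)butyl in place of 1-methylbutyl on an oxygen on an aromatic ring.

Among the measured compounds shown here, only one measured step bears on this change. That step, a 1.0-fold lower number from compound 1 to compound 2 (0.01 log units; within the scatter), swaps pentyl for 1-methylbutyl on the same oxygen and shows no shift beyond the scatter. Neither measured compound carries a diethylamino group, so the data do not give the size or direction of the new step directly. The structural change is larger than the measured one, so a step beyond the scatter towards a lower number is tentatively expected. The expected step is a 3.0-fold lower number from compound 2 to compound 3 (0.48 log units; beyond the scatter). For compound 3 the estimated value is 5000 nM, with an expected range of 1500 nM to 20000 nM.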

Compound 3, half-maximal inhibitory concentration: 13500 nM
The estimate for compound 3 lay 2.7-fold (0.43 log units) below the measured number; measured number inside the range.
By their numbers in this assay, from the lowest: compounds 3, 2 and 1 (each within the scatter of the next).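

In this assay, placing 4-(diethylamino)butyl on an oxygen on an aromatic ring in place of 1-methylbutyl gives a 1.1-fold lower number from compound 2 to compound 3 (0.05 log units; within the scatter), and placing diethylamino in place of methyl on the pentyl chain gives a 1.1-fold lower number from compound 1 to compound 3 (0.06 log units; within the scatter). The earlier pair compared only all-carbon chains, whereas these steps show that, at this position, the assay does not separate a chain carrying diethylamino from either the pentyl or the 1-methylbutyl chain. Nothing available explains why this exchange produces no step beyond the scatter.

On these data alone, all three compounds lie within the scatter of one another in this assay, so it remains open whether any group on this oxygen can move the number beyond the scatter. A shorter chain, a piperidine or morpholine in place of diethylamino, or a carboxylic acid on the chain could each test this, and the compounds shown also leave open whether the same holds when the shared core is changed elsewhere.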